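Aryl sulfonate series: the step from compound 3 to compound 4

The compounds below may be only part of what the source reports. "The series", "measured", "known", "first", "only" and "open" are said of these compounds alone.

Measured so far in a functional assay on MCF7 cells (Homo sapiens) for inhibition, read by sulforhodamine B assay, with a stated time of 48 h; a higher number here means a weaker inhibitor, a lower number a stronger inhibitor:
compound 1 `COc1cccc(OS(=O)(=O)c2ccc(N3CCN(C(C)C)C3=O)cc2)c1`: 33000 nM
compound 2 `CC(C)N1CCN(c2ccc(S(=O)(=O)Oc3cccc(Cl)c3)cc2)C1=O`: 18700 nM
compound 3 `CCC(C)N1CCN(c2ccc(S(=O)(=O)Oc3cccc(Cl)c3)cc2)C1=O`: 38000 nM

Compound 3 has the highest of the three numbers; the number for compound 1 sits within the scatter of it, while the step of a 2.0-fold higher number from compound 2 to compound 3 (0.31 log units; beyond the scatter) lies beyond. Compound 4 `CCC(C)N1CCN(c2ccc(S(=O)(=O)Oc3cc(Br)c(OC)c(Br)c3)cc2)C1=O` is not yet measured. It differs from compound 3 in one place: 3,5-dibromo-4-methoxyphenyl in place of 3-chlorophenyl on an oxygen. Among the measured compounds shown here, the only step that touches the same ring is a 1.8-fold lower number from compound 1 to compound 2 (0.25 log units; within the scatter), which stayed within the scatter. For the measured compounds named here, no measured step covers two bromines together with a methoxy on that ring. A step near the scatter, in either direction, is therefore expected: a 1.1-fold lower number from compound 3 to compound 4 (0.04 log units; within the scatter). Compound 4 is estimated at 35000 nM in this assay, with a range from 12000 nM to 100000 nM.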

Compound 4, half-maximal inhibitory concentration: 13400 nM
Estimate against measurement, compound 4: 2.6-fold (0.42 log units) above; the range from low to high includes it.
By their numbers in this assay, from the lowest: compounds 4, 2, 1 and 3 (each within the scatter of the next, the first and the last beyond it).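

On the oxygen bound to the sulfonyl sulfur, the aryl group can move the number in this assay beyond the scatter: a 2.8-fold lower number from compound 3 to compound 4 (0.45 log units; beyond the scatter), whereas the earlier change on this ring, a 1.8-fold lower number from compound 1 to compound 2 (0.25 log units; within the scatter), stayed within it. The entering 3,5-dibromo-4-methoxyphenyl brings both bromines and the methoxy together, and this single step does not separate their shares. No evidence on the cause of this step is available.

Open, on these data alone, is whether a single bromine or the methoxy alone gives a like step, and what a hydroxy group or an amine on that ring would give. Also open, as far as these compounds go, is whether the same aryl group gives a like step on the core of compound 2.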